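Ring-nitrogen side chain swap on a weakly active core

The compounds below may be only part of what the source reports. "The series", "measured", "known", "first", "only" and "open" are said of these compounds alone.

Measured so far:
compound 1, `CCCSc1nc(Cl)c2c(n1)N(CCNC(=O)OC(C)(C)C)C(C(=O)N1CCN(C)CC1)N2`: 51800 nM
compound 2, `CCCSc1nc(Cl)c2c(n1)N(Cc1ccccc1)C(C(=O)NCCNC(=O)OC(C)(C)C)N2`: a limit, > 64000 nM

For the measured compounds named here, in a functional assay on TE-1 cells (Homo sapiens) for antiproliferative activity, read by MTT assay, with a stated time of 72 h (a higher number here means a weaker inhibitor, a lower number a stronger inhibitor), compound 1 gives 51800 nM, the only actual number for the series. Compound 2 reaches only a limit of this assay, > 64000 nM. Compound 2 thus sits at the limit of > 64000 nM in this assay, at which 1 of the 2 values shown sits. Compound 3, `CCCSc1nc(Cl)c2c(n1)N(Cc1ccco1)C(C(=O)N1CCN(C)CC1)N2`, differs from compound 1 in one place: furan-2-yl in place of ((tert-butoxycarbonyl)amino)methyl on a saturated chain carbon bound to a nitrogen on an aromatic ring in a ring. Going by the values given here, no step between measured compounds exists to set a direction for this change, so the expectation is a step within the usual scatter. Compound 3 is expected at 40000 nM, between 12000 nM and 64000 nM. That expectation amounts to a 1.3-fold lower number from compound 1 to compound 3 (0.11 log units; within the scatter).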

Compound 3, half-maximal inhibitory concentration: 35000 nM
Compound 3: middle estimate off by 1.1-fold (0.06 log units), on the high side; low and high end bracket the measured number.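

In this assay, this position gives its first readable step: furan-2-yl in place of ((tert-butoxycarbonyl)amino)methyl gives a 1.5-fold lower number from compound 1 to compound 3 (0.17 log units; within the scatter), with the other parts of compound 1 unchanged. An open chain with a hydrogen-bond donor is thus exchanged for a five-membered aromatic ring with no hydrogen-bond donor, and the step stays within the scatter. Nothing measured here bears on a cause for this step.

Going by these compounds, whether a free primary amine, a carboxylic acid or a longer chain at this place would give a step beyond the scatter stays open. So does the part of the furan oxygen, which thiophen-2-yl would address.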